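Three cytotoxicity limits and an ester-bearing analogue

This account rests on a few compounds, and the source may have more. Where it says the series, first, only, none or still open, it means among the compounds named here.

In an ADME assay on MT4 cells (Homo sapiens) for cytotoxicity, read by MTT assay, with a stated time of 5 days (on this read-out higher numbers stand for lower toxicity in this test and lower numbers for higher toxicity in this test), compound 1 `Cc1cc(C)c(Oc2cc(Nc3ccc(C#N)cc3)ncc2C(=O)NCc2cn(Cc3ccccc3Cl)nn2)c(C)c1` gives >= 188000 nM, a limit of the test rather than a number. Compound 2 `Cc1cc(C)c(Oc2cc(Nc3ccc(C#N)cc3)ncc2C(=O)NCc2cn(Cc3ccc(F)cc3)nn2)c(C)c1` gives >= 153000 nM, again a limit. Compound 3 `Cc1cc(C)c(Oc2cc(Nc3ccc(C#N)cc3)ncc2C(=O)NCc2cn(Cc3ccc(Cl)cc3)nn2)c(C)c1` gives >= 120000 nM, also a limit. The steps a step that the two limits leave unreadable from compound 1 to compound 2, a step that the two limits leave unreadable from compound 1 to compound 3 and a step that the two limits leave unreadable from compound 2 to compound 3 therefore cannot be read, and compound 3 stands at one of three limits with no numbered value in the set. Compound 4 `CCOC(=O)CCn1cc(CNC(=O)c2cnc(Nc3ccc(C#N)cc3)cc2Oc2c(C)cc(C)cc2C)nn1` differs from compound 3 by (ethoxycarbonyl)methyl in place of 4-chlorophenyl on a saturated chain carbon bound to an aromatic nitrogen. No readable step bears on this change; all three measured compounds sit at limits (the limit of >= 120000 nM in this assay, at which 1 of the 3 values shown sits), (the limit of >= 153000 nM in this assay, at which 1 of the 3 values shown sits), (the limit of >= 188000 nM in this assay, at which 1 of the 3 values shown sits). Compound 4 is expected to remain at a limit, the step that the limit leaves unreadable from compound 3 to compound 4 being estimated as none beyond the scatter. For compound 4 the estimated value in this assay is 150000 nM, ranging from 60000 nM to 400000 nM.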

Compound 4, half-maximal cytotoxic concentration: 21500 nM
Estimate against measurement, compound 4: 7.0-fold (0.84 log units) above; measured number outside the range, below it.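

In this assay, among these compounds, the move to (ethoxycarbonyl)methyl on a saturated chain carbon bound to an aromatic nitrogen gives an at least 5.5-fold lower number from compound 3 to compound 4 (0.74 log units; beyond the scatter) and an at least 7.1-fold lower number from compound 2 to compound 4 (0.85 log units; beyond the scatter) and an at least 8.7-fold lower number from compound 1 to compound 4 (0.94 log units; beyond the scatter) as the only readable steps here. Compounds 1, 2 and 3 all sit at limits and their mutual steps cannot be read, whereas compound 4 shows that a change at this place can bring a numbered value. Nothing measured here gives a reason for the drop.

The single change both removes the ring and brings in the ester, and the compounds shown do not separate the two. Going by these compounds, how a carboxylic acid or an amine in place of the ethoxycarbonyl group would read in this assay stays open.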